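The source may hold more compounds than are shown below. What is called first, only, known or untested is meant among the compounds shown, and "the series" means these compounds.

Among the measured compounds shown here, compound 1 `Cn1cc(C2=C(c3nn(CCn4ccnc4)c4ncccc34)C(=O)N(c3ccccc3)C2=O)c2ccccc21` is one of two compounds measured in a functional assay on SMMC-7721 cells (Homo sapiens) for antiproliferative activity, read by MTT assay, with a stated time of 48 h; a higher number here means a weaker inhibitor, a lower number a stronger inhibitor. In this assay compound 1 gives > 100000 nM, which is a limit of the assay and not a number. Compound 2 `Cn1cc(C2=C(c3nn(CCn4ccnc4)c4ncccc34)C(=O)NC2=O)c2ccccc21` differs from compound 1 by hydrogen in place of phenyl on an amide-type nitrogen in a ring. In this assay compound 2 gives > 100000 nM, again a limit rather than a number. The step that the two limits leave unreadable from compound 1 to compound 2 can therefore not be read, and the limit of > 100000 nM in this assay, at which 2 of the 2 values shown sit, is all that the measured values show about compound 1. Compound 3 `Cn1cc(C2=C(c3nn(CCCCn4ccnc4)c4ncccc34)C(=O)N(c3ccccc3)C2=O)c2ccccc21` has not been measured; it differs from compound 1 by 2-(1H-imidazol-1-yl)ethyl in place of 1H-imidazol-1-yl on a saturated chain carbon, two bonds along the chain from an aromatic nitrogen. For the measured compounds named here, no measured step touches this part of the structure, so the lengthened chain has no measured counterpart. Because compound 1 gives only the limit > 100000 nM, compound 3 is expected to stay near that same limit. The step of a number no higher from compound 1 to compound 3 (the limit leaves the size open) is estimated to be none beyond the scatter. Compound 3 is therefore estimated at 100000 nM in this assay, with a range from 30000 nM to 300000 nM.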

Compound 3, half-maximal inhibitory concentration: 1760 nM
The estimate for compound 3 lay 57-fold (1.75 log units) above the measured number, and the stated range ends above it.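

In this assay, the part of compound 1 on a saturated chain carbon, two bonds along the chain from an aromatic nitrogen, proved to be a place where a change can be read: going from the 2-(1H-imidazol-1-yl)ethyl chain to the 4-(1H-imidazol-1-yl)butyl chain gives an at least 56-fold lower number from compound 1 to compound 3 (1.75 log units; beyond the scatter). The earlier pair differed only on the amide-type nitrogen, its step cannot be read, and neither of its compounds showed that this series could reach a measurable number at all. Compound 3 keeps the phenyl of compound 1, so this single change in chain length is what separates a limit of the assay from a number, and compound 3 alone stands clear of that limit: the limit of > 100000 nM in this assay, at which 2 of the 3 values shown sit.

From the compounds shown here alone, what remains open is how activity runs along the chain, whether the 3-(1H-imidazol-1-yl)propyl chain already brings part of the change and whether a longer chain, such as a hexyl linker, or an amine in place of the 1H-imidazol-1-yl group would hold it. Also open, going by these compounds, is what hydrogen in place of phenyl on the amide-type nitrogen does once the 4-(1H-imidazol-1-yl)butyl chain is present.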